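Inverting one ring stereocentre of compound 3

This account rests on a few compounds, and the source may have more. Where it says the series, first, only, none or still open, it means among the compounds named here.

In a functional assay on SW1573 cells (Homo sapiens) for antiproliferative activity, read by sulforhodamine B assay, with a stated time of 48 h (a higher number here means a weaker inhibitor of growth, a lower number a stronger inhibitor of growth), compound 3 (`COC(=O)/C=C/[C@H]1OCCC[C@H]1O[Si](C)(C)C(C)(C)C`) gives > 100000 nM, which is a limit and not a number. Compound 1 (`CC(C)(C)[Si](C)(C)O[C@@H]1CCCO[C@@H]1CO`) gives > 100000 nM, also a limit. Going by the values given here, compound 2 (`COC(=O)/C=C\[C@H]1OCCC[C@H]1O[Si](C)(C)C(C)(C)C`) gives 6300 nM, the only true number so far.

Compound 4 (`COC(=O)/C=C/[C@H]1OCCC[C@@H]1O[Si](C)(C)C(C)(C)C`) differs from compound 3 thus: the two compounds have the same atoms and bonds and differ only in configuration as drawn: 1 of 3 stereo elements differ; a stereocentre at a saturated ring carbon is drawn R in compound 3 and S in compound 4.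

Among the compounds with values here, no measured step inverts this stereocentre. The nearest evidence is an at least 15-fold higher number from compound 2 to compound 3 (1.20 log units; beyond the scatter), a large step that goes with the fact that compounds 2 and 3 differ only in the configuration as drawn, although there the double bond changes and not the ring carbon. an at least 15-fold lower number from compound 1 to compound 2 (1.20 log units; beyond the scatter) is also large but exchanges a substituent, while a step that the two limits leave unreadable from compound 1 to compound 3 gives no readable size. Compound 2 at 6300 nM shows that configuration alone can matter in this series, so a sizeable step is possible here. Starting from a limit, it could only appear as a lower number.

The expected outcome is an at least 2.5-fold lower number from compound 3 to compound 4 (0.39 log units; beyond the scatter), and a report of only a limit is about as likely. Compound 4 is estimated at 40000 nM, with an expected range of 6000 nM to 100000 nM.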

Compound 4, concentration for 50% growth inhibition: 47000 nM
Compound 4: the middle estimate sits 1.2-fold (0.07 log units) below what was measured; the measured number falls inside the stated range.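

In this assay, going by these compounds alone, an at least 2.1-fold lower number from compound 3 to compound 4 (0.32 log units; beyond the scatter), the first readable step at this stereocentre, and it can only come from configuration: the fact that compounds 3 and 4 differ only in the configuration as drawn. Compound 3 gives > 100000 nM, which is a limit and not a number, so this step has a lower bound and no exact size. The ring carbon therefore matters with the E double bond, yet a 7.5-fold higher number from compound 2 to compound 4 (0.87 log units; beyond the scatter), and with two stereo elements differing, this step cannot be divided between the double bond and the ring carbon.

Going by these compounds, whether inverting the ring carbon has a similar effect with the Z double bond of compound 2 remains open. On these data alone, it is also open how either configuration would fare with a carboxylic acid in place of the methyl ester, or a free hydroxyl in place of the silyl ether.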